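From a bromophenol to a pyrrole side chain

The source may report more compounds than this note shows. Statements on the series, on what has been measured and on what is new or still open speak of the compounds shown alone.

In a functional assay on A549 cells (Homo sapiens) for antiproliferative activity, read by MTT assay, with a stated time of 72 h (a higher number here means a weaker inhibitor, a lower number a stronger inhibitor), compound 1 `O=C(N/N=C/c1ccccc1)Nc1ccc(Oc2ccnc3[nH]ccc23)cc1` gives 17200 nM, while compound 2 `O=C(N/N=C/c1ccc(O)cc1Br)Nc1ccc(Oc2ccnc3[nH]ccc23)cc1` gives 5080 nM, the lower of the two numbers. Compound 3 `CN(C)CCCn1cccc1/C=N/NC(=O)Nc1ccc(Oc2ccnc3[nH]ccc23)cc1` carries 1-(3-(dimethylamino)propyl)-1H-pyrrol-2-yl in place of 2-bromo-4-hydroxyphenyl on a carbon with a double bond to nitrogen. Among the compounds with values here, only one measured step bears on this place, a 3.4-fold lower number from compound 1 to compound 2 (0.53 log units; beyond the scatter), and it is modest. Within the data shown here, no measured compound carries the entering group, so no firm direction can be expected. The expected change is small, a 1.3-fold lower number from compound 2 to compound 3 (0.10 log units; within the scatter). Compound 3 is estimated at 4000 nM, within an expected range of 1000 nM to 15000 nM.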

Compound 3, half-maximal inhibitory concentration: 2660 nM
Beside the measured number, compound 3's estimate is 1.5-fold (0.18 log units) above it; low and high end bracket the measured number.
By their numbers in this assay, from the lowest: compounds 3 and 2 (each within the scatter of the next); then compound 1.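

In this assay the new side chain gives a 1.9-fold lower number from compound 2 to compound 3 (0.28 log units; within the scatter), so a pyrrole bearing a basic-free name aside

Correction of the above wording follows in full: in this assay the change to 1-(3-(dimethylamino)propyl)-1H-pyrrol-2-yl gives a 1.9-fold lower number from compound 2 to compound 3 (0.28 log units; within the scatter), so this place on a carbon with a double bond to nitrogen takes a five-membered aromatic ring with no bromine or oxygen and no change that can be told from the scatter. Measured against phenyl, the same group gives a 6.5-fold lower number from compound 1 to compound 3 (0.81 log units; beyond the scatter) and thus also stands beyond the scatter. Nothing measured here offers a reason for these numbers.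

Whether the pyrrole ring or the 3-(dimethylamino)propyl chain accounts for the step from phenyl stays open. So does what an unsubstituted pyrrol-2-yl, a shorter aminoethyl chain or a morpholine in place of the dimethylamino group would give.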